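Putting a methyl back on compound 2

The source may report more compounds than this note shows. Statements on the series, on what has been measured and on what is new or still open speak of the compounds shown alone.

Among the measured compounds shown here, in a functional assay on Shh Light II cells (Mus musculus) for inhibition, read by a luciferase reporter (on this read-out lower numbers stand for stronger inhibition and higher numbers for weaker inhibition), compound 2 (`O=C(Nc1ccccc1Cl)N1CCC(c2nc(-c3ccc4ccccc4n3)no2)CC1`) gives 510 nM and holds the lowest number so far. Compound 1 (`C[C@@H]1C[C@H](c2nc(-c3ccc4ccccc4n3)no2)CCN1C(=O)Nc1ccccc1Cl`) gives 2400 nM and carries one extra methyl. For the measured compounds named here, the only measured step (a 4.7-fold lower number from compound 1 to compound 2 (0.67 log units; beyond the scatter)) removes that methyl, so it is the sole guide here. Compound 3 (`C[C@H]1C[C@H](c2nc(-c3ccc4ccccc4n3)no2)CCN1C(=O)Nc1ccccc1Cl`) differs from compound 2 by a methyl (methyl in place of hydrogen on a saturated ring carbon) on the same saturated ring carbon, next to the ring nitrogen, but in the opposite spatial arrangement to compound 1. A rise smaller than the measured step is therefore expected in this assay with wide uncertainty. The estimated step (a 2.2-fold higher number from compound 2 to compound 3 (0.33 log units; beyond the scatter)) is modest. Compound 3 is expected at 1100 nM (range 200 nM to 4500 nM).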

Compound 3, half-maximal inhibitory concentration: 900 nM
Beside the measured number, compound 3's estimate is 1.2-fold (0.09 log units) above it, and the stated range covers the measured number.
By their numbers in this assay, from the lowest: compounds 2 and 3 (each within the scatter of the next); then compound 1.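

Adding the methyl in the arrangement of compound 3 gives a 1.8-fold higher number from compound 2 to compound 3 (0.25 log units; within the scatter), so in this arrangement the methyl brings no change that can be told apart from scatter. Changing the arrangement at this one ring carbon gives a 2.7-fold lower number from compound 1 to compound 3 (0.43 log units; beyond the scatter), so the spatial arrangement of the methyl, not its mere presence, decides whether the number rises clearly: the fact that compounds 1 and 3 differ only in the configuration as drawn

From the compounds shown here alone, whether an ethyl or a hydroxymethyl group on this carbon would behave like the methyl stays open. So does the effect of inverting the other stereocentre.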